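Para-methyl on the phenyl of compound 3

The source may report more compounds than this note shows. Statements on the series, on what has been measured and on what is new or still open speak of the compounds shown alone.

Measured so far:
Compound 1 `CCS[C@@H]1[C@H](SCC)[C@@H](Cn2cc(-c3ccccc3)nn2)O[C@H]1n1ccc(=O)[nH]c1=O` gives 3040 nM in a functional assay on A549 cells (Homo sapiens) for cytotoxicity, read by MTT assay, with a stated time of 72 h; a higher number here means that more compound is needed for the effect, a lower number that less compound is needed.
Compound 2 `CCS[C@@H]1[C@H](SCC)[C@@H](Cn2cc(COC(C)=O)nn2)O[C@H]1n1ccc(=O)[nH]c1=O` reaches only the limit >= 100000 nM in this assay.
Compound 3 `CCS[C@@H]1[C@H](SCC)[C@@H](Cn2cc(-c3ccccc3)nn2)O[C@H]1n1cc(C)c(=O)[nH]c1=O` gives 31700 nM in this assay.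

Compound 3 holds the highest of the two numbers; the nearest is compound 1, with a 10-fold higher number from compound 1 to compound 3 (1.02 log units; beyond the scatter). The other measured step, an at least 32-fold higher number from compound 1 to compound 2 (1.51 log units; beyond the scatter), concerns the group on the triazole.

Compound 4 `CCS[C@@H]1[C@H](SCC)[C@@H](Cn2cc(-c3ccc(C)cc3)nn2)O[C@H]1n1cc(C)c(=O)[nH]c1=O` differs from compound 3 by methyl in place of hydrogen on an aromatic carbon. For the measured compounds named here, no measured step matches a methyl on the phenyl; the step of a 10-fold higher number from compound 1 to compound 3 (1.02 log units; beyond the scatter) concerns a methyl on the core, and an at least 32-fold higher number from compound 1 to compound 2 (1.51 log units; beyond the scatter) a different group altogether. A small step, within the scatter, is therefore expected in this assay: a 1.1-fold lower number from compound 3 to compound 4 (0.02 log units; within the scatter). Compound 4 is estimated at 30000 nM, between 10000 nM and 100000 nM.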

Compound 4, half-maximal effective concentration: 12300 nM
Compound 4: the middle estimate sits 2.4-fold (0.39 log units) above what was measured, within the range that was stated.
By their numbers in this assay, from the lowest: compound 1; then compound 4; then compound 3. At a limit, above all of these: compound 2.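

In this assay the change from phenyl to 4-methylphenyl gives a 2.6-fold lower number from compound 3 to compound 4 (0.41 log units; beyond the scatter) and so shows that this place on the phenyl responds to one added methyl. Its direction is opposite to that of a 10-fold higher number from compound 1 to compound 3 (1.02 log units; beyond the scatter) on the core, so a methyl does not act alike at the two places in these compounds. Nothing shown here gives a cause for the new step.

From the compounds shown here alone, whether methoxy or chlorine at this place on the phenyl would move the number further stays open. Going by these compounds, it also stays open whether the same change holds on compound 1, which lacks the methyl on the core.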